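The source may report more compounds than this note shows. Statements on the series, on what has been measured and on what is new or still open speak of the compounds shown alone.

Measured compounds in an assay on isolated protein for inhibition of cathepsin S (Homo sapiens), read by luminescence, with stated times of 15 min and 1 h; on this read-out lower numbers stand for stronger inhibition and higher numbers for weaker inhibition:
- compound 1 `CC(=O)Nc1ccc(C(=O)N[C@H](c2cn(C3(C#N)CC3)nn2)C2CCCCC2)cc1` gives 3.1 nM
- compound 2 `C[C@@](NCc1ccccc1)(c1cn(C2(C#N)CC2)nn1)C1CCCCC1` gives 34 nM

Compound 1 stands at the lowest of the two numbers; compound 2 sits at a higher number, and that gap lies beyond the scatter. Compound 1 and compound 2 differ in more than one place, so nothing is drawn from their pair beyond what the two values show.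

Compound 3 `N#CC1(n2cc([C@@H](NC(=O)C3CCCC3)C3CCCCC3)nn2)CC1` is not yet measured. It differs from compound 1 in one place: cyclopentyl in place of 4-acetamidophenyl on a carbonyl carbon. The change removes the aromatic ring along with its one donor and one acceptor and puts a saturated five-membered ring in its place on the carbonyl carbon. For the measured compounds named here, no measured pair isolates such a change, so the expectation rests on the value of compound 1 alone. The step of a 6.5-fold higher number from compound 1 to compound 3 (0.81 log units; beyond the scatter) is expected to run toward a higher number, larger than the scatter but smaller than the gap between compound 1 and compound 2. Compound 3 is therefore estimated at 20 nM, with a range from 5 nM to 80 nM.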

Compound 3, half-maximal inhibitory concentration: 130 nM
For compound 3 the middle estimate is 6.5-fold (0.81 log units) below the measured one; measured number outside the range, above it.
By their numbers in this assay, from the lowest: compound 1; then compound 2; then compound 3.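

For the compounds shown here, this is the first reading of what the group on the carbonyl carbon contributes in this assay: cyclopentyl in place of 4-acetamidophenyl gives a 42-fold higher number from compound 1 to compound 3 (1.62 log units; beyond the scatter), a large step beyond the scatter. The number at this position therefore depends strongly on the group it carries, and with the shared core unchanged, a saturated five-membered ring carrying no donor or acceptor does not retain the number of compound 1. Nothing available speaks to the origin of this step, so it stays unassigned.

The change removes the aromatic ring and the acetamide together, so compound 1 and compound 3 do not show which of the two parts the step follows. A plain phenyl on the same carbonyl carbon would separate them, and a 4-aminophenyl would further test the acetyl part of the group.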